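From ethoxy to phenoxy at the chain end

The compounds below may be only part of what the source reports. "The series", "measured", "known", "first", "only" and "open" are said of these compounds alone.

Compound 1 `COc1ccc(C(O)C2OC(=O)c3c(OC)cc(OC)cc32)cc1`: > 10000 nM, a limit
Compound 2 `CCOCCOc1ccc(C(O)C2OC(=O)c3c(OC)cc(OC)cc32)cc1`: > 10000 nM, a limit

In a functional assay on RAW264.7 cells (Mus musculus) for inhibition, read by Griess assay, with stated times of 1 h and 24 h (on this read-out higher numbers stand for weaker inhibition and lower numbers for stronger inhibition), compound 2 gives > 10000 nM, which is a limit and not a number. Compound 3 `COc1cc(OC)c2c(c1)C(C(O)c1ccc(OCCOc3ccccc3)cc1)OC2=O` carries phenyl in place of ethyl on an oxygen on a saturated carbon, turning 2-ethoxyethyl to 2-phenoxyethyl: phenyl in place of ethyl on an oxygen on a saturated carbon. Among the measured compounds shown here, the only measured step is a step that the two limits leave unreadable from compound 1 to compound 2, and both compounds sit at the limit of > 10000 nM in this assay, at which 2 of the 2 values shown sit. For the measured compounds named here, it therefore offers no size to carry over, and no step of known size or direction is expected in this assay. The expected step is a step that the limit leaves unreadable from compound 2 to compound 3. Compound 3 is estimated at 15000 nM, with an expected range from 5000 nM to 50000 nM.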

Compound 3, half-maximal inhibitory concentration: > 10000 nM
Compound 3 ended at the assay's limit; the forecaster's own chance of this, stated with the estimate: 75%; the middle value is on the limit's open side.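

No step among compound 1, compound 2 and compound 3 can be read in this assay, since all three end at a limit and not at a number: the limit of > 10000 nM in this assay, at which 3 of the 3 values shown sit.

On these data alone, how far each compound lies beyond that limit, and whether phenyl or ethyl makes any difference there, stays open.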